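A few compounds are considered here, and "the series" means these few. Any claim that something is new, unique, unknown or untested is made for them only; others in the source may bear on it.

In a functional assay on HCT-116 cells (Homo sapiens) for antiproliferative activity, read by MTT assay, with a stated time of 48 h (a higher number here means a weaker inhibitor, a lower number a stronger inhibitor), compound 3 `CCCCCCCCC(CCO)n1cnc2c(NC)ncnc21` gives 3730 nM, the lowest of the two plain numbers shown. Compound 1 `CCCCCCCC(CCO)n1cnc2c(NC)ncnc21` gives 12500 nM in this assay, and the step of a 3.4-fold lower number from compound 1 to compound 3 (0.53 log units; beyond the scatter) separates the two. For compound 2 `CCCCCCCC(CCO)n1cnc2c(N)ncnc21` this assay reports only a limit, > 50000 nM, which marks where the limit of > 50000 nM in this assay, at which 1 of the 3 values shown sits, sits. From compound 2 to compound 1 the change is methyl in place of hydrogen on a nitrogen on an aromatic ring, and it gives an at least 4.0-fold lower number from compound 2 to compound 1 (0.60 log units; beyond the scatter). Compound 4 `CCCCCCCCC(CCO)n1cnc2c(N(C)C)ncnc21` carries the same kind of change relative to compound 3: methyl in place of hydrogen on a nitrogen on an aromatic ring. The places differ, since here the nitrogen's other neighbours are aromatic carbon and saturated chain carbon, whereas in compound 2 they were aromatic carbon only. The difference between the cores of compound 2 and compound 3 is not broken down here. Because the earlier step of an at least 4.0-fold lower number from compound 2 to compound 1 (0.60 log units; beyond the scatter) was at least modest, a smaller gain is expected for compound 4, a 2.5-fold lower number from compound 3 to compound 4 (0.40 log units; beyond the scatter). Compound 4 is estimated at 1500 nM, between 300 nM and 8000 nM.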

Compound 4, half-maximal inhibitory concentration: 19800 nM
For compound 4 the middle estimate is 13-fold (1.12 log units) below the measured one, and the stated range ends below it.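

In this assay, adding the same methyl gives a 5.3-fold higher number from compound 3 to compound 4 (0.72 log units; beyond the scatter), so this change does not carry over from one core to the other in the same direction: the same change on two cores in this assay, an at least 4.0-fold lower number (0.60 log units; beyond the scatter) from compound 2 to compound 1 and a 5.3-fold higher number (0.72 log units; beyond the scatter) from compound 3 to compound 4, at least 21-fold (1.32 log units) apart, beyond the scatter of two such steps. For compound 2 the entry > 50000 nM is a limit of the assay and not a number, so the earlier step has a lower bound on its size rather than an exact size. These two pairs show that a gain on one core did not predict a gain on the other, but they do not show which difference between the cores is responsible or how the change would behave on any further core.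

The compounds shown leave open how an ethyl or an acetyl group on this nitrogen would behave. They also leave open what a carboxylic acid in place of the hydroxyl would do.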